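The compounds below may be only part of what the source reports. "The series", "measured", "known", "first", "only" and "open" are said of these compounds alone.

Three compounds share one core and differ only in the aromatic group on the saturated chain carbon bound to the amine nitrogen. Compound 1 `CC(C)(C)CCC1(NCc2ccc3ccccc3c2)C(=O)C(C2=NS(=O)(=O)c3cc(NS(C)(=O)=O)ccc3N2)=C(O)c2ccccc21` carries a naphthalen-2-yl group and in an in vivo ADME assay on the whole organism (strain Sprague-Dawley) for pharmacokinetics, with Rattus norvegicus as the target, at a dose of 5 mg/kg by the intravenous route (a lower number here means slower removal, a higher number faster removal of the compound), compound 1 gives 23.3 mL/min/kg. Compound 2 `COc1ccccc1CNC1(CCC(C)(C)C)C(=O)C(C2=NS(=O)(=O)c3cc(NS(C)(=O)=O)ccc3N2)=C(O)c2ccccc21` carries a 2-methoxyphenyl group, and compound 2 gives 25 mL/min/kg. Compound 3 `Cc1cccc(C)c1CNC1(CCC(C)(C)C)C(=O)C(C2=NS(=O)(=O)c3cc(NS(C)(=O)=O)ccc3N2)=C(O)c2ccccc21` carries a 2,6-dimethylphenyl group, and compound 3 gives 13 mL/min/kg, the lowest of the three numbers, though the steps of a 1.8-fold lower number from compound 1 to compound 3 (0.25 log units; within the scatter) and a 1.9-fold lower number from compound 2 to compound 3 (0.28 log units; within the scatter) both stay within the scatter, so no real separation is shown.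

Compound 4 `Cc1cccc(C)c1CN[C@]1(CCC(C)(C)C)C(=O)C(C2=NS(=O)(=O)c3cc(NS(C)(=O)=O)ccc3N2)=C(O)c2ccccc21` is the next step: the two compounds have the same atoms and bonds; at least one stereo element is drawn with a configuration in one of them and without one in the other: 1 of 1 stereo elements differ; a stereocentre at a saturated ring carbon is drawn without a configuration in compound 3 and S in compound 4. In words, nothing is added or removed; compound 4 is a single mirror-image form of what compound 3 describes without a fixed configuration. None of the measured steps changes a stereocentre, so no shown step bears directly on this change. A single form can in principle be cleared differently from the mixture, but nothing here shows this, so the expectation is a step of no change at the digits printed from compound 3 to compound 4 (within the scatter), within the scatter. Compound 4 is therefore estimated at 13 mL/min/kg, with a range from 7 mL/min/kg to 26 mL/min/kg.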

Compound 4, clearance: 11.7 mL/min/kg
For compound 4 the middle estimate is 1.1-fold (0.05 log units) above the measured one; the range from low to high includes it.
By their numbers in this assay, from the lowest: compounds 4, 3, 1 and 2 (each within the scatter of the next, the first and the last beyond it).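

The three earlier compounds vary only the aromatic group, so compound 4 gives the first view of the stereocentre at the saturated ring carbon. In this assay drawing that centre as S gives a 1.1-fold lower number from compound 3 to compound 4 (0.05 log units; within the scatter) and so shows no separation between the single S form and the drawing without a fixed configuration. The comparison is a clean one for this stereocentre, since the only thing that sets the two compounds apart is this: the fact that one of compounds 3 and 4 is drawn with a defined configuration and the other without, at the place where they differ.

From the compounds shown here alone, what the mirror-image R form would give at this stereocentre stays open, so the two single forms cannot yet be set against each other. Also open, going by these compounds, is whether the S form would give a similar number with naphthalen-2-yl, 2-methoxyphenyl or a pyridine ring in place of 2,6-dimethylphenyl.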